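The source may hold more compounds than are shown below. What is called first, only, known or untested is meant among the compounds shown, and "the series" means these compounds.

Of the compounds shown here, two that share one core have been tested in an ADME assay on a cell-free system (plasma, Homo sapiens) for metabolic stability; on this read-out higher numbers stand for a longer-lived compound and lower numbers for a shorter-lived compound. Compound 1 `C[C@@H]1C(=O)N(S(C)(=O)=O)[C@H]2CCN(C(=O)OCc3ccccc3)[C@H]12` carries a methylsulfonyl group on an amide-type nitrogen in a ring. In this assay compound 1 gives < 0.0834 h, which is a limit of the assay and not a number. Compound 2 `C[C@@H]1C(=O)N(c2ccc([N+](=O)[O-])cc2[N+](=O)[O-])[C@H]2CCN(C(=O)OCc3ccccc3)[C@H]12` gives > 24 h, and this too is a limit. On these data alone, compound 1 therefore stands at the short-lived end of the two results, but its exact half-life is unknown.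

Compound 3 `CC1CC1C(=O)N1C(=O)[C@@H](C)[C@@H]2[C@@H]1CCN2C(=O)OCc1ccccc1` has not yet been measured. It has (2-methylcyclopropyl)carbonyl in place of the methylsulfonyl of compound 1: (2-methylcyclopropyl)carbonyl in place of methylsulfonyl on an amide-type nitrogen in a ring. Among the measured compounds shown here, no measured pair shows what a change at this place does, so any forecast here is rough. Compound 1 reports the limit < 0.0834 h, so a shift towards longer life is the expected direction. The estimated step of an at least 23-fold higher number from compound 1 to compound 3 (1.37 log units; beyond the scatter) is expected to be large, well beyond the scatter. For compound 3 the estimated half-life is 2 h, with an expected range from 0.25 h to 15 h.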

Compound 3, half-life: 2.6 h
Beside the measured number, compound 3's estimate is 1.3-fold (0.11 log units) below it, and the stated range covers the measured number.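

Until now this nitrogen was known only through two limits. In this assay, among the compounds shown here, compound 3 gives 2.6 h, the first real number for the series. Putting (2-methylcyclopropyl)carbonyl in place of methylsulfonyl on an amide-type nitrogen in a ring gives an at least 31-fold higher number from compound 1 to compound 3 (1.49 log units; beyond the scatter), so a change at this one place is enough to move a compound from the short-lived limit to a half-life that can be measured. The true size of that step stays unknown because compound 1 gives a limit of the assay and not a number: the limit of < 0.0834 h in this assay, at which 1 of the 3 values shown sits.

The compounds shown do not separate the carbonyl from the three-membered ring of carbon, and a simple acetyl group or a longer carbon chain on the same nitrogen would help to tell which part of the new group goes with the longer half-life. On these data alone, how compound 3 ranks against compound 2 also stays open, since the result for compound 2 is a limit of the assay and not a number.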